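Nitro substitution on two cores in the A2780 series

This account rests on a few compounds, and the source may have more. Where it says the series, first, only, none or still open, it means among the compounds named here.

Compound 1 `CCn1cc(-c2nc3ccccc3[nH]2)c(=O)c2cc(F)c(N3CCNCC3)cc21` is the parent of the first pair. In a functional assay on A2780 cells (Homo sapiens) for cytotoxicity, read by MTT assay, with a stated time of 48 h (on this read-out higher numbers stand for weaker inhibition and lower numbers for stronger inhibition), compound 1 gives 800 nM. Compound 3 `CCn1cc(-c2nc3ccc([N+](=O)[O-])cc3[nH]2)c(=O)c2cc(F)c(N3CCNCC3)cc21` carries the change (nitro in place of hydrogen on an aromatic carbon), and in this assay compound 3 gives 1600 nM. The step of a 2.0-fold higher number from compound 1 to compound 3 (0.30 log units; within the scatter) therefore counts as no real shift on this read-out.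

Compound 2 `CCn1cc(-c2nc3ccccc3o2)c(=O)c2cc(F)c(N3CCNC(C)C3)c(F)c21` has a different core; the difference between the two cores is not broken down here. In this assay compound 2 gives 83500 nM, which places it far from both compound 1 and compound 3, with the gaps to each lying beyond the scatter.

Compound 4 `CCn1cc(-c2nc3ccc([N+](=O)[O-])cc3o2)c(=O)c2cc(F)c(N3CCNC(C)C3)c(F)c21` is the unmeasured member. It differs from compound 2 by nitro in place of hydrogen on an aromatic carbon, and the surroundings of the site are described in the same words as for the step from compound 1 to compound 3, so this is the same change made on the second core. Whether the second core answers this change as the first core did is not shown by the measured compounds; the only precedent is a 2.0-fold higher number from compound 1 to compound 3 (0.30 log units; within the scatter).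

Compound 4 is expected to sit close to compound 2, with an estimated step of a 1.8-fold higher number from compound 2 to compound 4 (0.25 log units; within the scatter), resting on the small step seen from compound 1 to compound 3 a 2.0-fold higher number from compound 1 to compound 3 (0.30 log units; within the scatter) and on the starting value of compound 2 83500 nM. The estimate for compound 4 is 150000 nM, with a likely range from 60000 nM to 400000 nM; given how weak compound 2 already is, there is a fair chance this assay reports only a limit for compound 4.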

Compound 4, half-maximal inhibitory concentration: 200 nM
Compound 4: the middle estimate sits 750-fold (2.88 log units) above what was measured; the whole stated range lies above it.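

Nitro in place of hydrogen on an aromatic carbon does not carry over from one core to the other in this assay: the same change on two cores in this assay, a 2.0-fold higher number (0.30 log units; within the scatter) from compound 1 to compound 3 and a 420-fold lower number (2.62 log units; beyond the scatter) from compound 2 to compound 4, 840-fold (2.92 log units) apart, beyond the scatter of two such steps

Within the data shown here, on the second core the change gives a 420-fold lower number from compound 2 to compound 4 (2.62 log units; beyond the scatter), a large step, so the small step on the first core was no guide to its size on the second. With a single pair on each core, and with the cores differing in more than one place, this shows that the effect of the change depends on the core, but it does not show which difference between the cores matters, why it matters, or how the change would behave on any third core.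

Left open is whether the large step belongs to nitro itself or whether another group on the same aromatic carbon of the core of compound 2, such as an amine or a nitrile, would give a step of similar size. Also open, going by these compounds, is which single difference between the two cores separates their responses, a question that would need pairs differing in one place only, for example with and without the extra methyl on the piperazine-type ring.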